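This account rests on a few compounds, and the source may have more. Where it says the series, first, only, none or still open, it means among the compounds named here.

Measured compounds:
compound 1 `O=C(Nc1cccc(-n2cc(-c3ccncc3)c(-c3ccc(Cl)c(O)c3)n2)c1)Nc1cccc(C(F)(F)F)c1` gives 2010 nM
compound 2 `O=C(Nc1cccc(-n2cc(-c3ccncc3)c(-c3ccc(Cl)c(O)c3)n2)c1)Nc1ccc(Cl)c(Cl)c1` gives 1310 nM

Both numbers come from a functional assay on SN12C cells (Homo sapiens) for inhibition, read by sulforhodamine B assay, with a stated time of 48 h; on this read-out lower numbers stand for stronger inhibition of growth and higher numbers for weaker inhibition of growth. On these two numbers compound 1 stands highest, and its nearest neighbour is compound 2, with a 1.5-fold lower number from compound 1 to compound 2 (0.19 log units; within the scatter) between them; the two compounds share the whole core and differ only in the aryl group on the urea-type nitrogen.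

Compound 3 `O=C(Nc1cccc(-n2cc(-c3ccncc3)c(-c3ccc(Cl)c(O)c3)n2)c1)Nc1cc(C(F)(F)F)cc(C(F)(F)F)c1` is not yet measured. It differs from compound 1 by trifluoromethyl in place of hydrogen on an aromatic carbon, so the aryl on that nitrogen now carries two trifluoromethyl groups instead of one. Within the data shown here, no measured step adds a second group to this ring; the only step available, from compound 1 to compound 2, swaps one substituted aryl for another and stays within the scatter, which suggests that this part of the molecule is not very sensitive to such changes. For compound 3 a step of about a 1.3-fold lower number from compound 1 to compound 3 (0.10 log units; within the scatter) is therefore expected, that is, nothing beyond the scatter, in this assay. The estimate for compound 3 is 1600 nM, with a range from 600 nM to 4500 nM.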

Compound 3, concentration for 50% growth inhibition: 1030 nM
For compound 3 the middle estimate is 1.6-fold (0.19 log units) above the measured one; the measured number falls inside the stated range.
By their numbers in this assay, from the lowest: compounds 3, 2 and 1 (each within the scatter of the next).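

Adding a second trifluoromethyl group to the aryl ring on the urea nitrogen gives, in this assay, a 2.0-fold lower number from compound 1 to compound 3 (0.29 log units; within the scatter). Until now this ring had only shown a swap of one substituted aryl for another, whereas this result shows that an added group of 4 heavy atoms, on an aromatic carbon that previously held hydrogen, also leaves the number within the scatter. No measurement among these compounds explains this outcome.

The aryl groups shown carry only trifluoromethyl or chlorine, so it remains open whether an amine or a carboxylic acid on this ring would also leave the number within the scatter. Also open, as far as these compounds go, is what a plain phenyl with no substituent at all would give in this assay.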